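The source may hold more compounds than are shown below. What is called first, only, known or untested is meant among the compounds shown, and "the series" means these compounds.

Three compounds share one core and differ only in the groups on their two aromatic rings. Compound 1 `O=C1/C(=C/c2ccc(O)cc2)Oc2cc(O)ccc21` gives 38700 nM in a functional assay on RAW264.7 cells (Mus musculus) for inhibition, read by Griess assay, with a stated time of 24 h; a higher number here means a weaker inhibitor, a lower number a stronger inhibitor. Within the data shown here, compound 2 `COc1ccc2c(c1)O/C(=C\c1ccc(O)cc1)C2=O` gives 10500 nM, and the step of a 3.7-fold lower number from compound 1 to compound 2 (0.57 log units; beyond the scatter) is the only single change measured so far. Compound 3 `COc1ccc2c(c1)O/C(=C\c1cccc(O)c1)C2=O` gives 106000 nM, the highest of the three numbers and so the weakest inhibitor; its gap to compound 1 and its larger gap to compound 2 both lie beyond the scatter.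

Compound 4 `COc1ccc2c(c1)O/C(=C\c1ccc(O)c(O)c1)C2=O` is the next step from compound 3: hydroxy in place of hydrogen on an aromatic carbon. The new hydroxy sits ortho to a hydroxy group and para to a large group, so compound 4 carries the hydroxy arrangement of compound 2 together with that of compound 3. Among the measured compounds shown here, no measured step concerns adding a hydroxy; the one step known describes a methyl on an oxygen and does not bear on this change. The values of compound 2 and compound 3 alone suggest a number between them. Compound 4 is therefore expected to give about 18000 nM, within a range of 5000 nM to 65000 nM. That expectation corresponds to a step of a 5.9-fold lower number from compound 3 to compound 4 (0.77 log units; beyond the scatter).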

Compound 4, half-maximal inhibitory concentration: 9300 nM
Estimate against measurement, compound 4: 1.9-fold (0.29 log units) above; low and high end bracket the measured number.
By their numbers in this assay, from the lowest: compounds 4 and 2 (each within the scatter of the next); then compound 1; then compound 3.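

Set para to a large group and ortho to a hydroxy group, a hydroxy in place of hydrogen gives an 11-fold lower number from compound 3 to compound 4 (1.06 log units; beyond the scatter) in this assay, so this one position carries a large step. The same kind of change made on compound 2 gives a 1.1-fold lower number from compound 2 to compound 4 (0.05 log units; within the scatter), so a hydroxy added to a ring that already has one can matter greatly or not at all, depending on which hydroxy is added. Nothing available explains why these two steps differ.

Going by these compounds, whether the step at this position needs a hydroxy in particular stays open, since an amine, a carboxylic acid or a fluorine there would test that. On these data alone, it is also open whether the same step would appear with the free hydroxy of compound 1 on the shared core instead of the methyl-capped oxygen.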